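This account rests on a few compounds, and the source may have more. Where it says the series, first, only, none or still open, it means among the compounds named here.

In a functional assay on COLO 205 cells (Homo sapiens) for inhibition, read by sulforhodamine B assay, with a stated time of 48 h, tested at 50 uM (on this read-out higher numbers stand for more inhibition of growth at the one concentration tested and lower numbers for less inhibition of growth), compound 2 `COc1cc(/C=C/C(=O)/C=C/c2cc(OC)c(OC)c(OC)c2)ccc1OCc1cn(CCCOc2cc(=O)oc3ccccc23)nn1` gives 74%, the highest of the three numbers recorded. Compound 3 `COc1ccc(/C=C/C(=O)/C=C/c2ccc(OCc3cn(CCCCOc4cc(=O)oc5ccccc45)nn3)c(OC)c2)cc1OC` gives 53%, a value below compound 2 by more than the scatter, and compound 1 `COc1ccccc1/C=C/C(=O)/C=C/c1ccc(OCc2cn(CCCCCOc3cc(=O)oc4ccccc34)nn2)c(OC)c1` gives 30%, further below still. Going by the values given here, no pair of these measured compounds differs in only one place, so no single step can be read off directly. Compound 4 `COc1ccc(/C=C/C(=O)/C=C/c2ccc(OCc3cn(CCCOc4cc(=O)oc5ccccc45)nn3)c(OC)c2)cc1` is not yet measured; it differs from compound 2 in one place: 4-methoxyphenyl in place of 3,4,5-trimethoxyphenyl on a double-bonded chain carbon bound to a double-bonded chain carbon. Since compound 2 with 74% gives the strongest growth inhibition seen, and compound 1 and compound 3, which also differ from it elsewhere, give less, a downward step beyond the scatter is expected in a number 24 percentage points lower from compound 2 to compound 4 (beyond the scatter). Compound 4 is estimated at 50%, within 30% to 70%.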

Compound 4, percent growth inhibition at one concentration: 53%
The estimate for compound 4 lay 3 percentage points below the measured number, and the stated range covers the measured number.
By their numbers in this assay, from the lowest: compound 1; then compounds 3 and 4 (each within the scatter of the next); then compound 2.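

In this assay, 4-methoxyphenyl in place of 3,4,5-trimethoxyphenyl on a double-bonded chain carbon bound to a double-bonded chain carbon gives a number 21 percentage points lower from compound 2 to compound 4 (beyond the scatter). Going by these compounds alone, this is the only comparison here that changes one place alone, so it shows that growth inhibition responds to the substitution of this aryl group with the rest of the structure held constant. Nothing available explains this step.

From the compounds shown here alone, it remains open whether an amine or a carboxylic acid on this ring would restore or further lower growth inhibition. Going by these compounds, it also remains open whether the step keeps its size with a longer chain elsewhere in the structure.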